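Working notes: from compound 2 to compound 4

The source may hold more compounds than are shown below. What is called first, only, known or untested is meant among the compounds shown, and "the series" means these compounds.

Measured so far. Compound 1 `O=C(Nc1ccccc1)c1csc(-c2cn(Cc3ccc(Cl)cc3)c3ccccc23)n1`: 32100 nM in a functional assay on HeLa cells (Homo sapiens) for cytotoxicity, read by MTT assay, with a stated time of 48 h, in the presence of a further agent that is not named here; a lower number here means a stronger inhibitor, a higher number a weaker inhibitor. Compound 2 `COc1ccc2[nH]cc(-c3nc(C(=O)Nc4cc(OC)c(OC)c(OC)c4)cs3)c2c1`: 9980 nM. Compound 3 `O=C(Nc1ccccc1)c1csc(-c2c[nH]c3ccccc23)n1` gives only a limit of the assay, > 100000 nM.

Among the numbers shown, compound 2 gives the lowest, with compound 1 above it; compound 3 sits at a limit (the limit of > 100000 nM in this assay, at which 1 of the 3 values shown sits).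

Compound 4 `COc1cc(NC(=O)c2csc(-c3c[nH]c4ccc(Br)cc34)n2)cc(OC)c1OC` differs from compound 2 by bromo in place of methoxy on an aromatic carbon. Within the data shown here, the only measured step, an at least 3.1-fold higher number from compound 1 to compound 3 (0.49 log units; beyond the scatter), concerns an aromatic nitrogen and not this ring position, so it gives no direct guide; the shared core carries no comparable change elsewhere.

With nothing bearing on it, the step from compound 2 to compound 4 is expected to be small, a 1.5-fold higher number from compound 2 to compound 4 (0.18 log units; within the scatter), not clearly beyond the scatter. Compound 4 is therefore estimated at 15000 nM, within 4000 nM to 60000 nM.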

Compound 4, half-maximal inhibitory concentration: 93000 nM
Compound 4: middle estimate off by 6.2-fold (0.79 log units), on the low side, and the stated range ends below it.
By their numbers in this assay, from the lowest: compound 2; then compound 1; then compound 4. At a limit, above all of these: compound 3.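

Within this assay bromo in place of methoxy gives a 9.3-fold higher number from compound 2 to compound 4 (0.97 log units; beyond the scatter) at this ring position, so the position is not neutral to the group it carries. The series now holds a step beyond the scatter on an aromatic carbon as well as on an aromatic nitrogen. Compound 3 is held at a limit of the assay, and the same end of the range would soon be met by any further rise from this position: the limit of > 100000 nM in this assay, at which 1 of the 4 values shown sits.

Only methoxy and bromo are compared at this position. On these data alone, how an amine, a hydroxyl or a longer alkoxy chain would read here stays open.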